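A few compounds are considered here, and "the series" means these few. Any claim that something is new, unique, unknown or untested is made for them only; others in the source may bear on it.

Four compounds share one core and differ in a single aromatic group, and all are judged in a functional assay on HCT-116 cells (Homo sapiens) for antiproliferative activity, read by MTT assay, with a stated time of 72 h; a higher number here means a weaker inhibitor, a lower number a stronger inhibitor. Compound 1 `O=C(CCc1cccc2c1B(O)OC2)Nc1cccc(-c2cccc(OC(F)(F)F)c2)c1` gives 310 nM, compound 2 `CSc1cccc(-c2cccc(NC(=O)CCc3cccc4c3B(O)OC4)c2)c1` gives 110 nM, and compound 3 `O=C(CCc1cccc2c1B(O)OC2)Nc1cccc(-c2ccc(C(F)(F)F)cc2)c1` gives 550 nM. Compound 3 cannot be told apart from compound 1 within the usual scatter of repeat measurements, while compound 2 stands clear of both as the strongest inhibitor of the three.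

The next change leads to compound 4 `CC(=O)c1cccc(-c2cccc(NC(=O)CCc3cccc4c3B(O)OC4)c2)c1`: 3-acetylphenyl in place of 4-(trifluoromethyl)phenyl on an aromatic carbon. Put simply, 3-acetylphenyl takes the place of 4-(trifluoromethyl)phenyl on an aromatic carbon.

Among the measured compounds shown here, no measured step involves an acetyl group, so any forecast rests on indirect evidence. The closest guide is a 5.0-fold higher number from compound 2 to compound 3 (0.70 log units; beyond the scatter), which installed the very group now leaving, in place of 3-(methylsulfanyl)phenyl. A second guide, a 2.8-fold lower number from compound 1 to compound 2 (0.45 log units; beyond the scatter), shows that a swap on this outer ring can also shift the number modestly. Compound 4 shares the 3-substituted phenyl form of compound 2, so part of that loss may be regained, though probably not all of it. The expected change is a 2.2-fold lower number from compound 3 to compound 4 (0.34 log units; beyond the scatter), a modest move towards a lower number. For compound 4 the estimated value is 250 nM, with an expected range of 90 nM to 700 nM.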

Compound 4, half-maximal inhibitory concentration: 86 nM
Estimate against measurement, compound 4: 2.9-fold (0.46 log units) above; measured number below the stated range.
By their numbers in this assay, from the lowest: compounds 4 and 2 (each within the scatter of the next); then compounds 1 and 3 (each within the scatter of the next).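

Replacing 4-(trifluoromethyl)phenyl with 3-acetylphenyl gives a 6.4-fold lower number from compound 3 to compound 4 (0.81 log units; beyond the scatter) in this assay, and this step takes the series back to the level of the methylsulfanyl compound, as the acetyl and methylsulfanyl groups cannot be told apart here, with a 1.3-fold lower number from compound 2 to compound 4 (0.11 log units; within the scatter). Acetyl also beats trifluoromethoxy on the same outer ring, with a 3.6-fold lower number from compound 1 to compound 4 (0.56 log units; beyond the scatter), so this position does not simply favour or disfavour substitution: two quite different groups, one of them carrying a hydrogen-bond acceptor by count and the other not listed as such here, land together while trifluoromethoxy stands apart. No measured property of these groups is available to explain any of these steps.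

The step from compound 3 to compound 4 changes both the group and the place where it sits on the ring, so the compounds shown cannot say how much of the gain belongs to each. They also leave open how an amine, a carboxylic acid or a longer chain would read in place of the acetyl group in this assay, and whether the level shared by the acetyl and methylsulfanyl compounds can be passed.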